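The source may report more compounds than this note shows. Statements on the series, on what has been measured and on what is new or still open speak of the compounds shown alone.

Measured so far:
compound 1 `NC(=O)[C@@H]1CC[C@H](c2ccc(OCc3ccc(F)cc3)cc2)N1`: > 63000 nM
compound 2 `NC(=O)CN1Cc2ccc(OCc3ccccc3F)cc2C1`: > 100000 nM

In an assay on HEK293 cells for inhibition of sodium channel protein type 3 subunit alpha (Homo sapiens), read by electrophysiology, with a stated time of 3.5 min (a lower number here means a stronger inhibitor, a higher number a weaker inhibitor), compound 1 gives > 63000 nM, which is a limit of the assay and not a number (the limit of > 63000 nM in this assay, at which 1 of the 2 values shown sits). Compound 2 gives > 100000 nM, again only a limit (the limit of > 100000 nM in this assay, at which 1 of the 2 values shown sits). For the measured compounds named here, compound 1 therefore stands at a limit, and the one other value shown is a limit as well, so no order between the two can be read from these numbers.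

Compound 3 `NC(=O)[C@@H]1CC[C@H](c2ccc(OCc3ccccc3)cc2)N1` is not yet measured. It differs from compound 1 by hydrogen in place of fluoro on an aromatic carbon. Going by the values given here, no step between measured compounds is known, so the expectation rests on compound 1 alone: with compound 1 at a limit, the step in this assay is expected to be none beyond the scatter, and a limit is again the likely outcome. The expected step that the limit leaves unreadable from compound 1 to compound 3 is thus flat. Compound 3 is expected at 80000 nM, within 30000 nM to 300000 nM.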

Compound 3, half-maximal inhibitory concentration: > 63000 nM
Compound 3: a limit, no number; the forecaster's own chance of this, stated with the estimate: 85%; the middle value is on the limit's open side.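

Compound 1 and compound 3 each give only a limit of the assay and not a number, so no step can be read between them. Still open is whether 4-fluorophenyl to phenyl alters inhibition at all, and what concentration any compound shown would actually need.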